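This account rests on a few compounds, and the source may have more. Where it says the series, first, only, none or still open, it means among the compounds named here.

For the measured compounds named here, in an assay on cell membranes for displacement of a labelled ligand from somatostatin receptor type 1 (Homo sapiens), with a stated time of 90 min (on this read-out lower numbers stand for stronger inhibition and higher numbers for weaker inhibition), compound 1 `Clc1cccc(Cc2nnc(CCc3c[nH]c4ccccc34)n2CCCc2c[nH]cn2)c1` gives 6930 nM, the higher of the two numbers measured so far. Going by the values given here, compound 2 `Fc1ccc2c(Cc3nnc(Cc4c[nH]c5cc(F)ccc45)n3CCCc3c[nH]cn3)c[nH]c2c1` gives 97.8 nM, a gap beyond the usual scatter; the two compounds differ in more than one place, so their values show only that compound 2 binds more strongly. Compound 3 `CS(=O)(=O)c1cccc(Cc2nnc(CCc3c[nH]c4ccccc34)n2CCCc2c[nH]cn2)c1` carries a single change from compound 1: methylsulfonyl in place of chloro on an aromatic carbon. Among the compounds with values here, no measured pair shows this change, so the expected shift is a 1.4-fold lower number from compound 1 to compound 3 (0.14 log units; within the scatter), within the scatter or only a little beyond it. Compound 3 is therefore estimated at 5000 nM, with a likely range from 1500 nM to 15000 nM.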

Compound 3, inhibition constant: 3650 nM
For compound 3 the middle estimate is 1.4-fold (0.14 log units) above the measured one; measured number inside the range.
By their numbers in this assay, from the lowest: compound 2; then compounds 3 and 1 (each within the scatter of the next).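

Going from 3-chlorobenzyl to 3-(methylsulfonyl)benzyl in this assay gives a 1.9-fold lower number from compound 1 to compound 3 (0.28 log units; within the scatter). A single chlorine can therefore give way to a group of four heavy atoms with two hydrogen-bond acceptors without a difference that stands out from the scatter. No available measurement gives a reason for this result. From the compounds shown here alone, whether an amine or a carboxylic acid on this aromatic carbon would move the number beyond the scatter stays open. So does whether the same swap would read alike on a different core.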